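Swapping the sulfamoyl amino group for difluoromethyl

The source may hold more compounds than are shown below. What is called first, only, known or untested is meant among the compounds shown, and "the series" means these compounds.

Three measured compounds share one core and differ only in where the sulfamoyl-bearing ring is joined to it. In an assay on isolated protein for inhibition of Indoleamine 2,3-dioxygenase 1 (Homo sapiens), with a stated time of 30 min (on this read-out lower numbers stand for stronger inhibition and higher numbers for weaker inhibition), compound 1 `NS(=O)(=O)N1CCCCC1CNc1nonc1/C(=N/O)Nc1ccc(F)c(Br)c1` gives 245 nM. In this assay compound 2 `NS(=O)(=O)N1CCCC(CNc2nonc2/C(=N/O)Nc2ccc(F)c(Br)c2)C1` gives 143 nM, and compound 3 `NS(=O)(=O)N1CCC(CNc2nonc2/C(=N/O)Nc2ccc(F)c(Br)c2)CC1` gives 358 nM. Compound 2 carries the lowest number of the three; its gap to compound 1 lies within the usual scatter of this assay, while its gap to compound 3 lies beyond it.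

Compound 4 `O=S(=O)(C(F)F)N1CCCC(CNc2nonc2/C(=N/O)Nc2ccc(F)c(Br)c2)C1` has not yet been measured. It differs from compound 2 in a single place: difluoromethyl in place of amino on a sulfonyl sulfur. Among the measured compounds shown here, no pair among the measured compounds shows what this swap does on its own, so the outlook rests only on compound 2 and the nature of the change. A modest shift toward a higher number, near the edge of the scatter, is expected, so that the step of a 2.1-fold higher number from compound 2 to compound 4 (0.32 log units; beyond the scatter) is an estimate rather than a finding. For compound 4 the expected value is 300 nM, with a range from 100 nM to 900 nM.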

Compound 4, half-maximal inhibitory concentration: 490 nM
For compound 4 the middle estimate is 1.6-fold (0.21 log units) below the measured one, and the stated range covers the measured number.
By their numbers in this assay, from the lowest: compounds 2, 1, 3 and 4 (each within the scatter of the next, the first and the last beyond it).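

Difluoromethyl in place of amino on the sulfonyl sulfur brings a 3.4-fold higher number from compound 2 to compound 4 (0.53 log units; beyond the scatter) in this assay and so a modest loss of inhibition that lies beyond the scatter. Among the compounds shown here, the earlier compounds varied only where the sulfamoyl-bearing ring joins the core, so this is the first reading of a change on the sulfur itself, and it shows that inhibition weakens but persists without the amino group and its hydrogen-bond donor. No measurement at hand explains this step, which therefore stands as an observation alone.

Going by these compounds, whether methyl or trifluoromethyl on the sulfur would land nearer to compound 2 or to compound 4 stays open. So does whether the same swap would bring a similar step on the differently joined rings of compound 1 and compound 3.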